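The compounds below may be only part of what the source reports. "The series", "measured", "known", "first", "only" and "open" are said of these compounds alone.

In a functional assay on HT-29 cells (Homo sapiens) for antiproliferative activity, read by MTT assay, with a stated time of 48 h (a lower number here means a stronger inhibitor of growth, a higher number a weaker inhibitor of growth), compound 1 `COC(=O)N1N=C(c2ccccc2)CC1c1ccc(OC)c(O)c1` gives 3500 nM, while compound 2 `COC(=O)N1N=C(c2ccccc2)CC1c1ccc(OC)c(OC)c1` gives 10700 nM. Compound 2 therefore has the higher of the two numbers and is the weaker inhibitor of growth of this pair. Compound 3 `COC(=O)N1N=C(c2ccccc2)CC1c1cc(OC)c(OC)cc1OC` differs from compound 2 in one place: methoxy in place of hydrogen on an aromatic carbon. Among the compounds with values here, no measured step shows this exact change. Within the data shown here, the only step available, a 3.1-fold higher number from compound 1 to compound 2 (0.49 log units; beyond the scatter), is modest and beyond the scatter, but it comes from a different change, methyl in place of hydrogen on an oxygen on an aromatic ring. It offers only weak guidance, so no clear direction can be expected, and no shift beyond the scatter is predicted. The expected step is a 1.1-fold lower number from compound 2 to compound 3 (0.03 log units; within the scatter), with wide uncertainty. For compound 3 the estimated value is 10000 nM, with an expected range from 3500 nM to 30000 nM.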

Compound 3, concentration for 50% growth inhibition: 14900 nM
Estimate against measurement, compound 3: 1.5-fold (0.17 log units) below; low and high end bracket the measured number.
By their numbers in this assay, from the lowest: compound 1; then compounds 2 and 3 (each within the scatter of the next).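

Placing a methoxy group on this aromatic carbon, ortho to a large group, meta to one methoxy group and para to another, gives a 1.4-fold higher number from compound 2 to compound 3 (0.14 log units; within the scatter) in this assay. This ring position can therefore carry a methoxy group in place of hydrogen with no difference that stands out from the usual scatter. By contrast, the earlier change on an oxygen gave a 3.1-fold higher number from compound 1 to compound 2 (0.49 log units; beyond the scatter), and nothing available explains the result at this ring position.

From the compounds shown here alone, it remains open whether a different group on this carbon, such as an amine or a carboxylic acid, would shift the number beyond the scatter. It is also unknown whether the same methoxy group would give a similar step on compound 1, which carries a hydroxy group.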